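Sulfur-linked chain variation on the shared core

This account rests on a few compounds, and the source may have more. Where it says the series, first, only, none or still open, it means among the compounds named here.

Measured compounds:
compound 1 `CSc1nc(NCc2ccc(-c3ccccn3)cc2)c2[nH]nc(C(C)C)c2n1` 783 nM
compound 2 `CC(C)c1n[nH]c2c(NCc3ccc(-c4ccccn4)cc3)nc(SCCCN(C)C)nc12` 105 nM
compound 3 `CNCCSc1nc(NCc2ccc(-c3ccccn3)cc2)c2[nH]nc(C(C)C)c2n1` 56 nM

In a functional assay on HT cells (Homo sapiens) for antiproliferative activity, read by fluorescence, with a stated time of 72 h (a lower number here means a stronger inhibitor of growth, a higher number a weaker inhibitor of growth), compound 2 stands second highest of the three numbers. Its nearest neighbour is compound 3 with a 1.9-fold lower number from compound 2 to compound 3 (0.27 log units; within the scatter); its furthest is compound 1 with a 7.5-fold lower number from compound 1 to compound 2 (0.87 log units; beyond the scatter). Compound 3 also sits far from compound 1, with a 14-fold lower number from compound 1 to compound 3 (1.15 log units; beyond the scatter).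

Compound 4 `C=CCSc1nc(NCc2ccc(-c3ccccn3)cc2)c2[nH]nc(C(C)C)c2n1` is not yet measured. Against compound 2 the change is vinyl in place of 2-(dimethylamino)ethyl on a saturated chain carbon bound to a sulfur. Compound 4 thus carries a short chain without the nitrogen, as compound 1 does. The steps from compound 1 to compound 2 and to compound 3 bear directly: each addition of an amine-bearing chain gave a clearly lower number, so its removal is expected to go the other way. The step from compound 2 to compound 4 is expected as a 5.7-fold higher number from compound 2 to compound 4 (0.76 log units; beyond the scatter), toward the number of compound 1. For compound 4 the estimate is 600 nM, with a range from 200 nM to 2000 nM.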

Compound 4, concentration for 50% growth inhibition: 1010 nM
Beside the measured number, compound 4's estimate is 1.7-fold (0.23 log units) below it; the range from low to high includes it.
By their numbers in this assay, from the lowest: compounds 3 and 2 (each within the scatter of the next); then compounds 1 and 4 (each within the scatter of the next).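

Compound 1 and compound 4 stand level (a 1.3-fold higher number from compound 1 to compound 4 (0.11 log units; within the scatter)) in this assay, so vinyl in place of hydrogen on this saturated chain carbon bound to a sulfur does not reproduce the lower numbers of the nitrogen-bearing chains. Removing the nitrogen-bearing chain costs clearly, with a 9.6-fold higher number from compound 2 to compound 4 (0.98 log units; beyond the scatter) and an 18-fold higher number from compound 3 to compound 4 (1.26 log units; beyond the scatter) both beyond the scatter, so among these compounds the lower numbers go only with the chains carrying an amine. No measurement at hand explains this difference.

Open, as far as these compounds go, is whether the nitrogen itself matters or chain length also contributes, which a plain butyl chain or a 3-hydroxypropyl chain would separate. From the compounds shown here alone, a carboxylic acid on the chain is also open.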